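This account rests on a few compounds, and the source may have more. Where it says the series, first, only, none or still open, it means among the compounds named here.

Measured so far:
compound 1, `COc1ccc([C@@H]2[C@@H](Oc3ccccc3)C(=O)N2c2cc(OC)c(OC)c(OC)c2)cc1`, 6900 nM;
compound 2, `COc1cc(N2C(=O)[C@@H](Oc3ccccc3)[C@H]2c2cccc([N+](=O)[O-])c2)cc(OC)c1OC`, 30000 nM.

In a functional assay on MCF7 cells (Homo sapiens) for antiproliferative activity, read by MTT assay, with stated times of 24 h and 72 h (on this read-out higher numbers stand for weaker inhibition and lower numbers for stronger inhibition), compound 2 gives the highest of the two numbers; compound 1 gives the lower one, and that gap lies beyond the scatter. Compound 3, `COc1cc(N)c([C@@H]2[C@H](Oc3ccccc3)C(=O)N2c2cc(OC)c(OC)c(OC)c2)cc1O`, has not been measured. It differs from compound 2 in one place: a group of 10 heavy atoms (7 carbon, 1 nitrogen, 2 oxygen; one six-membered aromatic ring of carbon only) in place of a group of 9 heavy atoms (6 carbon, 1 nitrogen, 2 oxygen; one six-membered aromatic ring of carbon only), on a saturated ring carbon. Going by the values given here, no measured pair shows this change, so its effect is unknown. The step from compound 2 to compound 3 is expected to lower the number by a modest amount, a 20-fold lower number from compound 2 to compound 3 (1.30 log units; beyond the scatter), though the uncertainty is wide. Compound 3 is estimated at 1500 nM, within 150 nM to 15000 nM.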

Compound 3, half-maximal inhibitory concentration: 20000 nM
The estimate for compound 3 lay 13-fold (1.12 log units) below the measured number, outside the stated range (above it).
By their numbers in this assay, from the lowest: compound 1; then compounds 3 and 2 (each within the scatter of the next).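

In this assay, putting the group of compound 3 in place of the 3-nitrophenyl on this saturated ring carbon gives a 1.5-fold lower number from compound 2 to compound 3 (0.18 log units; within the scatter). This pair therefore shows that a change of aromatic group that adds hydrogen-bond donors need not move the number beyond normal repeat variation. No measurement shown explains this result.

The compounds shown leave open whether a non-aromatic group at this carbon, such as a carboxylic acid or a short alkyl chain, would read differently. They also cannot separate the contribution of each substituent on the entering ring.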